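Aryl substituent exchange on the shared core: fluoro to methylsulfanyl

The source may report more compounds than this note shows. Statements on the series, on what has been measured and on what is new or still open speak of the compounds shown alone.

Three compounds of one shared core have numbers in hand. Compound 1 `CCOC(=O)C1=C(C)NC(=S)NC1C1CCCCC1` gives 0.46 ug/mL in a functional assay on PC-3 cells (Homo sapiens) for inhibition, read by sulforhodamine B assay, with a stated time of 48 h; a lower number here means a stronger inhibitor of growth, a higher number a weaker inhibitor of growth. Compound 2 `CCOC(=O)C1=C(C)NC(=S)NC1c1ccc(O)c(O)c1` gives 25 ug/mL in this assay. Compound 3 `CCOC(=O)C1=C(C)NC(=S)NC1c1ccc(F)cc1` gives 1.7 ug/mL in this assay, which places it second highest of the three numbers: the gap to the nearest, compound 1, is beyond the scatter, and the larger gap to compound 2 is beyond it as well. Within the data shown here, no pair of measured compounds differs in only one place, so no measured single step can be cited.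

Compound 4 `CCOC(=O)C1=C(C)NC(=S)NC1c1ccc(SC)cc1` has not yet been measured in this assay. It differs from compound 3 by methylsulfanyl in place of fluoro on an aromatic carbon. Among the measured compounds shown here, nothing among the measured compounds isolates this exchange. The expectation is a change no larger than the usual scatter, leaning if at all toward a lower number, so the step expected in this assay is a 1.4-fold lower number from compound 3 to compound 4 (0.15 log units; within the scatter). Compound 4 is accordingly expected to give about 1.2 ug/mL in this assay, within a range from 0.4 ug/mL to 4 ug/mL.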

Compound 4, concentration for 50% growth inhibition: 23.6 ug/mL
For compound 4 the middle estimate is 20-fold (1.29 log units) below the measured one, outside the stated range (above it).
By their numbers in this assay, from the lowest: compound 1; then compound 3; then compounds 4 and 2 (each within the scatter of the next).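

In this assay, among these compounds, the aromatic carbon carrying fluoro, para to a large group, proves sensitive to its substituent: methylsulfanyl in place of fluoro gives a 14-fold higher number from compound 3 to compound 4 (1.14 log units; beyond the scatter), the first single-place step and a large one. The exchange replaces one heavy atom with two and adds one hydrogen-bond acceptor, and this modest change in the counts is enough to weaken growth inhibition well beyond the scatter. Nothing at hand accounts for the size of this step.

Going by these compounds, whether the loss follows the sulfur or the added methyl carbon stays open, and a methoxy or a chloro group at this position would help separate the two. Whether the same exchange carries the same penalty at other positions on the aromatic ring is also unresolved.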